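Compound 1 and the sulfur-linked aryl change

A few compounds are considered here, and "the series" means these few. Any claim that something is new, unique, unknown or untested is made for them only; others in the source may bear on it.

Among the compounds with values here, in a functional assay on HGC-27 cells (Homo sapiens) for inhibition, read by MTT assay, with a stated time of 72 h (a lower number here means a stronger inhibitor, a higher number a weaker inhibitor), compound 1 `Cc1cc(N2CC[C@@H](C)[C@@H](N(C)c3ncnc4[nH]ccc34)C2)n2nc(SCc3ccccc3Br)nc2n1` gives 21300 nM, the only number so far. Compound 2 `Cc1nc2nc(SCc3ccc(Cl)cc3)nn2c(N2CC[C@@H](C)[C@@H](N(C)c3ncnc4[nH]ccc34)C2)c1C` reports only a limit, > 100000 nM. Compound 3 `CCCCCc1c(C)nc2nc(SCc3ccc(Cl)cc3)nn2c1N1CC[C@@H](C)[C@@H](N(C)c2ncnc3[nH]ccc23)C1` is likewise a limit, > 100000 nM.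

Compound 4 `Cc1ccc(CSc2nc3nc(C)cc(N4CC[C@@H](C)[C@@H](N(C)c5ncnc6[nH]ccc56)C4)n3n2)cc1` departs from compound 1 by 4-methylphenyl in place of 2-bromophenyl on a saturated chain carbon bound to a sulfur, with 4-methylphenyl in place of 2-bromophenyl on a saturated chain carbon bound to a sulfur. Within the data shown here, the one measured step, a step that the two limits leave unreadable from compound 2 to compound 3, lies at another place and gives no size to carry over. The nearest guide is the limit of > 100000 nM in this assay, at which 2 of the 3 values shown sit, and with compound 1 at 21300 nM a modest move towards weaker inhibition is expected. The expected step runs a 1.6-fold higher number from compound 1 to compound 4 (0.22 log units; within the scatter). Compound 4 is estimated at 35000 nM, with an expected range of 10000 nM to 100000 nM.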

Compound 4, half-maximal inhibitory concentration: 15200 nM
Beside the measured number, compound 4's estimate is 2.3-fold (0.36 log units) above it, within the range that was stated.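

In this assay, within the data shown here, the sulfur-linked position gives the first readable step, a 1.4-fold lower number from compound 1 to compound 4 (0.15 log units; within the scatter) for 4-methylphenyl in place of 2-bromophenyl on a saturated chain carbon bound to a sulfur. The two values lie within the scatter of each other, so this exchange, which takes out the bromine, shows no readable effect at this position. The step from compound 2 to compound 3 still cannot be read.

Going by these compounds, whether an amine or a carboxylic acid on this benzyl ring would move the number beyond the scatter stays open. Readable numbers remain few, and the rest are limits: the limit of > 100000 nM in this assay, at which 2 of the 4 values shown sit.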